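Hydroxyphenyl for Thiophenyl on the Pyridine-Bearing Core

This account rests on a few compounds, and the source may have more. Where it says the series, first, only, none or still open, it means among the compounds named here.

Of the compounds shown here, three have been measured in a functional assay on HCT-116 cells (Homo sapiens) for inhibition, with a stated time of 72 h; on this read-out higher numbers stand for weaker inhibition and lower numbers for stronger inhibition. Compound 1 `NC1CCC(Nc2nc(NCc3ccc(-c4ccsc4)cc3)c3ncn(C4CCCC4)c3n2)CC1` and compound 2 `NC1CCC(Nc2nc(NCc3ccc(-c4ccsc4)nc3)c3ncn(C4CCCC4)c3n2)CC1` differ in the aryl group carried by the side chain: 6-(thiophen-3-yl)pyridin-3-yl in place of 4-(thiophen-3-yl)phenyl on a saturated chain carbon bound to a nitrogen on an aromatic ring. In this assay compound 1 gives 315 nM, while compound 2 gives 145 nM, so that the step is a 2.2-fold lower number from compound 1 to compound 2 (0.34 log units; beyond the scatter). Compound 3 `NC1CCC(Nc2nc(NCc3ccc(-c4ccccc4O)cc3)c3ncn(C4CCCC4)c3n2)CC1` is compound 1 with one exchange at the far end of the chain: 2-hydroxyphenyl in place of thiophen-3-yl on an aromatic carbon. In this assay compound 3 gives 4350 nM, and the step from its parent is a 14-fold higher number from compound 1 to compound 3 (1.14 log units; beyond the scatter).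

Compound 4 `NC1CCC(Nc2nc(NCc3ccc(-c4ccccc4O)nc3)c3ncn(C4CCCC4)c3n2)CC1` is not yet measured. It stands to compound 2 as compound 3 stands to compound 1: 2-hydroxyphenyl in place of thiophen-3-yl on an aromatic carbon. The change is the same kind of change, though the surroundings differ: in compound 2 the place is on an aromatic carbon of a six-membered aromatic ring with 1 nitrogen, next to the ring nitrogen, para to a large group, whereas in compound 1 it is on an aromatic carbon of a six-membered aromatic ring of carbon only, para to a large group. For the measured compounds named here, with only one measured instance of this change, the expectation rests on the large step seen from compound 1 to compound 3, a 14-fold higher number from compound 1 to compound 3 (1.14 log units; beyond the scatter), and a weakening of similar size is expected from compound 2 to compound 4, a 14-fold higher number from compound 2 to compound 4 (1.14 log units; beyond the scatter). Compound 4 is therefore estimated to give 2000 nM in this assay, with a likely span from 700 nM to 6000 nM.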

Compound 4, half-maximal inhibitory concentration: 35 nM
The estimate for compound 4 lay 57-fold (1.76 log units) above the measured number, and the stated range ends above it.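

In this assay, the exchange of thiophen-3-yl for 2-hydroxyphenyl on the ring with 1 nitrogen gives a 4.1-fold lower number from compound 2 to compound 4 (0.62 log units; beyond the scatter), which runs the opposite way to the earlier 14-fold higher number from compound 1 to compound 3 (1.14 log units; beyond the scatter). The exchange therefore does not carry over from one core to the other in this series, in either size or direction, and the two cores differ only in that ring nitrogen: the same change on two cores in this assay, a 14-fold higher number (1.14 log units; beyond the scatter) from compound 1 to compound 3 and a 4.1-fold lower number (0.62 log units; beyond the scatter) from compound 2 to compound 4, 57-fold (1.76 log units) apart, beyond the scatter of two such steps. This shows that the outcome of the exchange depends on the core that carries it, but one pair of steps does not show why this is so, and it gives no rule that would hold for any other core or any other exchange at this place.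

The compounds shown leave open whether the reversal goes with the hydroxyl group or with the six-membered carbon ring that replaces the thiophene, as the exchange changes both at once. A plain phenyl group and a 2-methoxyphenyl group, each set on both cores, would separate these two parts of the change and show whether the hydroxyl hydrogen is what matters.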